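Methyl in place of tert-butoxy on a carbonyl carbon

The source may report more compounds than this note shows. Statements on the series, on what has been measured and on what is new or still open speak of the compounds shown alone.

In a functional assay on PANC-1 cells (Homo sapiens) for inhibition, read by XTT assay, with a stated time of 72 h (on this read-out lower numbers stand for stronger inhibition and higher numbers for weaker inhibition), compound 1 `CC(C)(C)OC(=O)N1CCC[C@H]1COCCCCCC/C=C/c1ccc(-c2ccccc2)cc1` gives > 100000 nM as a limit of the assay and not a number. Going by the values given here, compound 2 `CC(C)(C)OC(=O)N1CCC[C@H]1COCCCCCC/C=C/c1ccc(Oc2ccccc2)cc1` gives 63300 nM and compound 3 `CC(=O)N1CCC[C@H]1COCCCCCCCCC/C=C/c1ccc(-c2ccccc2)cc1` gives 70000 nM within the scatter of each other, and these are the only two true numbers in the set.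

Compound 4 `CC(=O)N1CCC[C@H]1COCCCCCC/C=C/c1ccc(Oc2ccccc2)cc1` differs from compound 2 by one change methyl in place of tert-butoxy on a carbonyl carbon that puts methyl in place of tert-butoxy on a carbonyl carbon. Among the compounds with values here, no measured step makes this change on its own. Within the data shown here, the one step at hand an at least 1.5-fold lower number from compound 1 to compound 2 (0.19 log units; that floor lies within the scatter) concerns phenoxy in place of phenyl on an aromatic carbon, so it says little here. Compound 3 also carries the acetyl and gives 70000 nM in the same range as compound 2.

The expected step of a 1.1-fold higher number from compound 2 to compound 4 (0.03 log units; within the scatter) is therefore none beyond the scatter. Compound 4 is estimated at 68000 nM within a range of 30000 nM to 100000 nM in this assay when it is measured.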

Compound 4, half-maximal inhibitory concentration: 40000 nM
Beside the measured number, compound 4's estimate is 1.7-fold (0.23 log units) above it, within the range that was stated.
By their numbers in this assay, from the lowest: compounds 4, 2 and 3 (each within the scatter of the next). At a limit, above all of these: compound 1.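

Going by these compounds alone, compound 4 gives the first direct reading of tert-butoxycarbonyl to acetyl on the shared core, in this assay: a 1.6-fold lower number from compound 2 to compound 4 (0.20 log units; within the scatter). Tert-butoxy, with 5 heavy atoms, can thus give way to methyl, with 1 heavy atom, on this carbonyl carbon without a shift beyond the scatter, at least with the phenoxy group in place. The set as a whole stays weak on this read-out, and one of its values is a limit and not a number: the limit of > 100000 nM in this assay, at which 1 of the 4 values shown sits.

Whether the same change behaves alike with the phenyl group cannot be read, as compound 1 and compound 3 differ in more than one place. As far as these compounds go, it also remains open whether an amine on this carbonyl carbon, or a free amine with the carbonyl gone, would move the number beyond the scatter.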